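This account rests on a few compounds, and the source may have more. Where it says the series, first, only, none or still open, it means among the compounds named here.

Measured compounds in a functional assay on U-87MG ATCC cells (Homo sapiens) for inhibition, read by MTT assay, with a stated time of 72 h; on this read-out higher numbers stand for weaker inhibition and lower numbers for stronger inhibition:
compound 1 `COc1cc2c(Oc3ccc(NC(=O)c4nn(-c5ccccc5OC(F)(F)F)c(=O)cc4C)cc3F)ccnc2cc1OCCCN1CCCC1`, 1280 nM
compound 2 `COc1cc2c(Oc3ccc(NC(=O)c4nn(-c5ccccc5OC(F)(F)F)c(=O)cc4C)cc3F)ccnc2cc1OCCCN1CCC(C)CC1`, 800 nM

Among the measured compounds shown here, compound 2 carries the lowest of the two numbers in this assay, but its only neighbour, compound 1, sits within the scatter of it; the one measured step, a 1.6-fold lower number from compound 1 to compound 2 (0.20 log units; within the scatter), is too small to call a difference in potency. Compound 3 `COc1cc2c(Oc3ccc(NC(=O)c4nn(-c5ccccc5OC(F)(F)F)c(=O)cc4C)cc3F)ccnc2cc1OCCCN1CCN(C)CC1` is not yet measured. It differs from compound 2 in one place: 4-methylpiperazin-1-yl in place of 4-methylpiperidin-1-yl on a saturated chain carbon, three bonds along the chain from an oxygen on an aromatic ring. For the measured compounds named here, the only step that bears on this change is the exchange of amine rings at the same chain position, a 1.6-fold lower number from compound 1 to compound 2 (0.20 log units; within the scatter), which stayed within the scatter. On that basis no step beyond the scatter is expected for compound 3 in this assay, a 1.1-fold higher number from compound 2 to compound 3 (0.05 log units; within the scatter). Compound 3 is therefore estimated at 900 nM, with a range from 400 nM to 2000 nM.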

Compound 3, half-maximal inhibitory concentration: 1440 nM
Compound 3: the middle estimate sits 1.6-fold (0.20 log units) below what was measured; the measured number falls inside the stated range.
By their numbers in this assay, from the lowest: compounds 2, 1 and 3 (each within the scatter of the next).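

In this assay, 4-methylpiperazin-1-yl in place of 4-methylpiperidin-1-yl, a change that adds a second ring nitrogen and a second hydrogen-bond acceptor, gives a 1.8-fold higher number from compound 2 to compound 3 (0.26 log units; within the scatter), and the same group in place of pyrrolidin-1-yl gives a 1.1-fold higher number from compound 1 to compound 3 (0.05 log units; within the scatter). All three amine rings at this place on the chain therefore remain within the scatter of one another, so the added ring nitrogen produces no readable step here. No measured property is available to account for these small steps.

Still open, on these data alone, is whether morpholin-4-yl, an unsubstituted piperazin-1-yl or an open-chain dimethylamino group at this place would produce a step beyond the scatter. Equally open, as far as these compounds go, is whether a longer chain between the aromatic oxygen and the amine ring would do so.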